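Notes on compounds 1 to 4: estimating compound 4

The source may report more compounds than this note shows. Statements on the series, on what has been measured and on what is new or still open speak of the compounds shown alone.

Measured so far in a functional assay for agonist activity at growth hormone secretagogue receptor type 1 (Homo sapiens), read by FLIPR; a higher number here means that more compound is needed for the effect, a lower number that less compound is needed:
compound 1 `C[C@@H]1CN(c2cccc(NS(=O)(=O)c3ccc(-c4ccccn4)s3)c2)C[C@H](C)N1` — 39.8 nM
compound 2 `C[C@@H]1CN(c2cc(NS(=O)(=O)c3ccc(-c4ccccn4)s3)ccc2C#N)C[C@H](C)N1` — 631 nM
compound 3 `COc1cccc(-c2ccc(S(=O)(=O)Nc3cc(N4C[C@@H](C)N[C@@H](C)C4)ccc3OC)cc2)c1` — 2 nM

Compound 3 stands lowest of the three numbers in this assay. Its nearest neighbour is compound 1, already beyond the scatter; compound 2 lies furthest away, also beyond the scatter. Among the compounds with values here, only one single-point step is available among the measured compounds, a 16-fold higher number from compound 1 to compound 2 (1.20 log units; beyond the scatter), a large step for a cyano in place of hydrogen on an aromatic carbon.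

Compound 4 `COc1ccc(N2C[C@@H](C)N[C@@H](C)C2)cc1NS(=O)(=O)c1ccc(-c2ccc(C)o2)cc1` differs from compound 3 in one place: 5-methylfuran-2-yl in place of 3-methoxyphenyl on an aromatic carbon. Within the data shown here, the one measured step concerns a different position and a different group, so nothing measured bears directly on this change. Among the measured compounds shown here, with no comparable step in the set, the expectation is a step of modest size in this assay, direction uncertain, and the estimate stays close to compound 3 with a wide range.

Compound 4 is therefore estimated at 5 nM, with a range from 1.5 nM to 25 nM. This estimate corresponds to an expected step of a 2.5-fold higher number from compound 3 to compound 4 (0.40 log units; beyond the scatter).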

Compound 4, half-maximal effective concentration: 0.794 nM
Beside the measured number, compound 4's estimate is 6.3-fold (0.80 log units) above it; the whole stated range lies above it.
By their numbers in this assay, from the lowest: compound 4; then compound 3; then compound 1; then compound 2.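

In this assay, 5-methylfuran-2-yl in place of 3-methoxyphenyl on this aromatic carbon gives a 2.5-fold lower number from compound 3 to compound 4 (0.40 log units; beyond the scatter), a modest step in the favourable direction. This position, para to a large group, therefore accepts a five-membered aromatic ring with one hetero atom and fewer heavy atoms, and a six-membered aromatic ring of carbon only is not required here for a low number. No measurement on hand explains the direction of this step.

Going by these compounds, it remains open whether the step belongs to the furan ring itself or to its methyl group, which a plain furan-2-yl would separate. Also open, on these data alone, is how an aminomethyl group or a carboxylic acid on the outer ring would read at this position.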